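This account rests on a few compounds, and the source may have more. Where it says the series, first, only, none or still open, it means among the compounds named here.

In a functional assay on SGC-7901 cells (Homo sapiens) for antiproliferative activity, read by MTT assay, with a stated time of 72 h (on this read-out lower numbers stand for stronger inhibition and higher numbers for weaker inhibition), compound 1 (`COc1ccc(-c2cc(C(=O)O)sc2-c2cc(OC)c(OC)c(OC)c2)cc1[N+](=O)[O-]`) gives 21600 nM and compound 2 (`COc1ccc(-c2cc(C(=O)O)sc2-c2cc(OC)c(OC)c(OC)c2)cc1O`) gives 17500 nM. The measured step between them is a 1.2-fold lower number from compound 1 to compound 2 (0.09 log units; within the scatter), so the two cannot be told apart. Compound 3 (`COc1ccc(-c2ccsc2-c2cc(OC)c(OC)c(OC)c2)cc1[N+](=O)[O-]`) departs from compound 1 by a single change, hydrogen in place of carboxy on an aromatic carbon. Among the measured compounds shown here, the one measured step, a 1.2-fold lower number from compound 1 to compound 2 (0.09 log units; within the scatter), concerns a different place, and both of its compounds keep the carboxy, so it gives no size for this change. For the measured compounds named here, no measured pair removes the carboxy, and any size named here is a judgement. With the carboxy in place, compound 1 stands at 21600 nM, and a clearly lower number is expected without it, by an uncertain margin. The expected step is an 11-fold lower number from compound 1 to compound 3 (1.03 log units; beyond the scatter). Compound 3 is estimated at 2000 nM, with an expected range from 150 nM to 15000 nM.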

Compound 3, half-maximal inhibitory concentration: 10300 nM
Compound 3: middle estimate off by 5.2-fold (0.71 log units), on the low side; low and high end bracket the measured number.
By their numbers in this assay, from the lowest: compounds 3, 2 and 1 (each within the scatter of the next, the first and the last beyond it).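

In this assay, the carboxy on this aromatic carbon of the five-membered aromatic ring with 1 sulfur proves dispensable for the antiproliferative read-out. Hydrogen in its place gives a 2.1-fold lower number from compound 1 to compound 3 (0.32 log units; beyond the scatter), the size of this change, which the earlier pair could not supply as both of its compounds keep the carboxy. The data shown offer no measurement that bears on the reason for this step.

Going by these compounds, it remains open whether another group on this carbon, such as a methyl ester, a primary amide or a hydroxymethyl, would take the number further down or back up. Also open, on these data alone, is whether losing the carboxy has a step of the same size when hydroxy stands in place of nitro, as in compound 2.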